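Side-chain variation on a shared amide core, in mice

A few compounds are considered here, and "the series" means these few. Any claim that something is new, unique, unknown or untested is made for them only; others in the source may bear on it.

Measured so far:
compound 1 `N=C(N)NCCC[C@H](NC(=O)CN(c1nc(Cl)nc2c1ncn2C1CCCCO1)C1CC1)C(=O)OCc1ccccc1` — 61.6%
compound 2 `CC[C@H](C)[C@H](NC(=O)CN(c1nc(Cl)nc2c1ncn2C1CCCCO1)C1CC1)C(=O)OCc1ccccc1` — 22.6%

In a functional assay on the whole organism with Mus musculus as the target, with a stated time of 90 min, at a dose of 25 umol/kg by the oral route (on this read-out lower numbers stand for a weaker effect and higher numbers for a stronger effect at the one dose given), compound 1 gives 61.6%. Compound 2 gives 22.6%, the lower of the two numbers; the step of a number 39 percentage points lower from compound 1 to compound 2 (beyond the scatter) is the only one measured. Compound 3 `CSCC[C@H](NC(=O)CN(c1nc(Cl)nc2c1ncn2C1CCCCO1)C1CC1)C(=O)OCc1ccccc1` carries 2-(methylsulfanyl)ethyl in place of sec-butyl on a saturated chain carbon bound to an amide-type nitrogen and a carbonyl carbon. Among the compounds with values here, the one measured step swapped in a different group, so it gives no direct guide here. The expected step is estimated as a number 3.4 percentage points higher from compound 2 to compound 3 (within the scatter). Compound 3 is estimated at 26%, range 8% to 48%.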

Compound 3, a percentage reported as activity, at one dose (the size of the read-out at that dose, not a potency): 42.7%
Estimate against measurement, compound 3: 16.7 percentage points below; the range from low to high includes it.
By their numbers in this assay, from the lowest: compound 2; then compound 3; then compound 1.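

In this assay, this position responds even when the group keeps 4 heavy atoms and no ring: 2-(methylsulfanyl)ethyl in place of sec-butyl gives a number 20.1 percentage points higher from compound 2 to compound 3 (beyond the scatter), so size alone does not set the read-out. The 2-(methylsulfanyl)ethyl group closes only part of the gap to the side chain of compound 1, with a number 18.9 percentage points lower from compound 1 to compound 3 (beyond the scatter) still separating the two. No supporting data explain either step.

Whether the sulfur or the unbranched chain accounts for the gain stays open. An unbranched butyl chain would separate the two, and a terminal amine would show how much of the level of compound 1 a smaller nitrogen group retains.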